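Aryl ketone series: chloro on the benzoyl ring

The source may hold more compounds than are shown below. What is called first, only, known or untested is meant among the compounds shown, and "the series" means these compounds.

Measured so far in a functional assay on T47D cells (Homo sapiens) for inhibition, read by sulforhodamine B assay, with a stated time of 48 h; a higher number here means a weaker inhibitor of growth, a lower number a stronger inhibitor of growth:
compound 1 `O=C(/C(=C/c1ccccc1)CCl)c1ccccc1` gives 18000 nM
compound 2 `O=C(/C(=C/c1ccc(Cl)cc1)CCl)c1ccccc1` gives 17000 nM
compound 3 `CC(=O)OC/C(=C\C1CCCCC1)C(=O)c1ccccc1` gives 22000 nM

The three measured compounds sit close together. Among the compounds with values here, the step of a 1.1-fold lower number from compound 1 to compound 2 (0.02 log units; within the scatter) is the only single-point comparison available; its change is chloro in place of hydrogen on an aromatic carbon. Compound 3 differs from compound 1 in a chain and an acetate in place of the chloromethyl; the difference between the two cores is not broken down here. Compound 3 gives the highest number of the three, but its gap to compound 1 and to compound 2 lies within the scatter, so no ordering among them is claimed.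

Compound 4 `CC(=O)OC/C(=C\C1CCCCC1)C(=O)c1ccc(Cl)cc1` is the unmeasured member. It differs from compound 3 by chloro in place of hydrogen on an aromatic carbon. This is the same change as that from compound 1 to compound 2, made on the same kind of position, and that earlier step was flat. Within the data shown here, with only one precedent, and that one within the scatter, the expectation for compound 4 rests on compound 3 carrying over essentially unchanged: the step of a 1.1-fold lower number from compound 3 to compound 4 (0.04 log units; within the scatter) is the estimated size, because the measured 1.1-fold lower number from compound 1 to compound 2 (0.02 log units; within the scatter) was of that size. Whether the different core of compound 3 alters the response to chloro cannot be told from these data. The estimate for compound 4 in this assay is 20000 nM, with an expected span from 10000 nM to 40000 nM.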

Compound 4, concentration for 50% growth inhibition: 18000 nM
Beside the measured number, compound 4's estimate is 1.1-fold (0.05 log units) above it, and the stated range covers the measured number.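

Phenyl to 4-chlorophenyl on the core of compound 3 gives a 1.2-fold lower number from compound 3 to compound 4 (0.09 log units; within the scatter) in this assay, so this step, like the earlier one, stays inside the usual variation between repeat measurements. Set side by side, the two steps show no detectable difference between the cores: the same change on two cores in this assay, a 1.1-fold lower number (0.02 log units; within the scatter) from compound 1 to compound 2 and a 1.2-fold lower number (0.09 log units; within the scatter) from compound 3 to compound 4, 1.2-fold (0.06 log units) apart, within the scatter of two such steps

This supports only a limited statement: on these two cores, chloro in place of hydrogen on an aromatic carbon leaves the growth-inhibition number unresolved from that of the parent compound. It does not show that the change would stay flat on a further core, and an effect smaller than the scatter could go unseen in either pair.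

Still open, on these data alone, is whether a group other than chloro at this place, such as methoxy, an amine or a carboxylic acid, would give a step beyond the scatter on either core. Also open, as far as these compounds go, is whether a longer chain in place of the acetate of compound 3 would separate the numbers, and whether the response to chloro would then remain the same.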